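A few compounds are considered here, and "the series" means these few. Any claim that something is new, unique, unknown or untested is made for them only; others in the source may bear on it.

Compound 1 `O=C(c1ccc(F)cc1)N1CCc2nc(COc3ccc(F)c(F)c3)oc2C1` and compound 2 `O=C(c1ccccc1)N1CCc2nc(COc3cccc(F)c3)oc2C1` were both tested in a functional assay on HEK293 cells for positive allosteric modulation of metabotropic glutamate receptor 5 (Homo sapiens), read by calcium flux; a lower number here means a smaller maximal response, a higher number a larger maximal response. In this assay compound 1 gives 40%, and compound 2 gives 73%. Of these two numbers compound 2 stands highest, and its gap to compound 1 lies beyond the usual scatter. Compound 3 `O=C(c1c(F)cccc1F)N1CCc2nc(COc3cccc(F)c3)oc2C1` has not been measured yet. It differs from compound 2 in one place: 2,6-difluorophenyl in place of phenyl on a carbonyl carbon. Within the data shown here, no step of exactly this kind has been measured, so the expected change a number 11 percentage points lower from compound 2 to compound 3 (beyond the scatter) is a small decrease, not clearly beyond the scatter. Compound 3 is expected to give 62%, within a range from 38% to 85%.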

Compound 3, largest response reached (reported as percent of maximum), in percent of the reference or control that the assay uses: 82%
Compound 3: middle estimate off by 20 percentage points, on the low side; the measured number falls inside the stated range.
By their numbers in this assay, from the lowest: compound 1; then compounds 2 and 3 (each within the scatter of the next).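

Putting 2,6-difluorophenyl in place of phenyl on a carbonyl carbon gives a number 9 percentage points higher from compound 2 to compound 3 (within the scatter) in this assay. This is the first comparison shown that changes this position alone, and it shows that the fluorine-bearing ring keeps the maximal response within the scatter of that of the plain phenyl ring. No measurement shown offers a reason for this result.

Going by these compounds, it remains open how this position would respond to a group other than a phenyl ring, such as a pyridine ring or a cyclohexyl group. Whether a methyl or chlorine on the ring would be tolerated in the same way is also unknown.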